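Swapping the dimethylphenyl arm for a tolyl arm

The source may hold more compounds than are shown below. What is called first, only, known or untested is meant among the compounds shown, and "the series" means these compounds.

Two analogues have been measured so far. Compound 1 `Cc1cc(C#N)cc(C)c1Oc1nc(Nc2ccc(C#N)cc2)ncc1-c1ccccc1` gives 31800 nM in an ADME assay on MT4 cells (Homo sapiens) for cytotoxicity, read by MTT assay, with a stated time of 5 days; a higher number here means that more compound is tolerated, a lower number that less compound is tolerated. Compound 2 `Cc1cc(C)cc(-c2cnc(Nc3ccc(C#N)cc3)nc2Oc2c(C)cc(C#N)cc2C)c1` gives 39000 nM in this assay. Among the measured compounds shown here, compound 2 therefore stands highest of the two numbers, yet its only neighbour is compound 1, and the step of a 1.2-fold higher number from compound 1 to compound 2 (0.09 log units; within the scatter) does not rise above the scatter, so the two cannot be ordered.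

Compound 3 `Cc1ccc(-c2cnc(Nc3ccc(C#N)cc3)nc2Oc2c(C)cc(C#N)cc2C)cc1` has not yet been measured. It differs from compound 2 by 4-methylphenyl in place of 3,5-dimethylphenyl on an aromatic carbon. For the measured compounds named here, the only step that bears on this change is the one at the same aromatic carbon, a 1.2-fold higher number from compound 1 to compound 2 (0.09 log units; within the scatter), which shows that swapping one carbon-only six-membered ring for another at this position left the cytotoxic concentration essentially unchanged. On that basis no step beyond the scatter is expected in this assay, in either direction. The step from compound 2 to compound 3 is estimated at a 1.1-fold lower number from compound 2 to compound 3 (0.05 log units; within the scatter). For compound 3 the expected value in this assay is 35000 nM, with a range from 17000 nM to 70000 nM.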

Compound 3, half-maximal cytotoxic concentration: 26100 nM
Beside the measured number, compound 3's estimate is 1.3-fold (0.13 log units) above it, within the range that was stated.
By their numbers in this assay, from the lowest: compounds 3, 1 and 2 (each within the scatter of the next).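

The position now carries phenyl, 4-methylphenyl and 3,5-dimethylphenyl, and in this assay the two new steps, a 1.5-fold lower number from compound 2 to compound 3 (0.17 log units; within the scatter) and a 1.2-fold lower number from compound 1 to compound 3 (0.09 log units; within the scatter), leave all three compounds within the scatter of one another. Among the compounds shown here, the earlier pair tested only two methyl groups on the phenyl ring at the aromatic carbon ortho to the 4-cyano-2,6-dimethylphenoxy group, whereas compound 3 adds the case of a single methyl at the 4-position, and this arrangement does not separate it from either neighbour. Nothing in the data accounts for these numbers or says what lies behind them.

All three arms are six-membered aromatic rings of carbon only, carrying nothing but methyl or hydrogen, so the compounds shown leave open whether an amine or a carboxylic acid on that ring, or a pyridine in its place, would give a step beyond the scatter. They also leave open what a much smaller group at this carbon, such as a single methyl or a bromine in place of the whole ring, would do to the tolerated concentration.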